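The compounds below may be only part of what the source reports. "The series", "measured", "known", "first", "only" and "open" are said of these compounds alone.

In a functional assay on MDA-MB-231 cells (Homo sapiens) for cytotoxicity, read by MTT assay, with a stated time of 48 h (on this read-out higher numbers stand for weaker inhibition and lower numbers for stronger inhibition), three compounds built on a shared core have been measured so far. Compound 1 (`O=c1ccoc2cc(OCc3cn(Cc4ccccc4)nn3)ccc12`) gives > 100000 nM as a limit of the assay, not a number. Compound 2 (`Cc1ccc(Cn2cc(COc3ccc4c(=O)ccoc4c3)nn2)cc1`) gives > 100000 nM as a limit too, so it has no exact place on the scale. Compound 3 (`O=c1ccoc2cc(OCc3cn(Cc4ccc(Cl)cc4)nn3)ccc12`) gives > 100000 nM as a limit as well. Among the compounds with values here, the series so far comes down to the limit of > 100000 nM in this assay, at which 3 of the 3 values shown sit, and no exact number.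

Compound 4 (`O=c1ccoc2cc(OCc3cn(Cc4cccc(Br)c4)nn3)ccc12`) is still unmeasured. It differs from compound 2 by 3-bromophenyl in place of 4-methylphenyl on a saturated chain carbon bound to an aromatic nitrogen with 3-bromophenyl in place of 4-methylphenyl on a saturated chain carbon bound to an aromatic nitrogen.

Within the data shown here, the steps that bear on this change are a step that the two limits leave unreadable from compound 1 to compound 2 with methyl for hydrogen, a step that the two limits leave unreadable from compound 1 to compound 3 with chloro for hydrogen, and a step that the two limits leave unreadable from compound 2 to compound 3 with chloro for methyl. None of them has a readable size, so they point in no direction. The expected change is a number no higher from compound 2 to compound 4 (the limit leaves the size open) with no shift beyond the scatter foreseen. Compound 4 is estimated at 100000 nM with an expected range from 40000 nM to 200000 nM in this assay and is expected to end up possibly as only a limit.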

Compound 4, half-maximal inhibitory concentration: > 100000 nM
Compound 4: a limit, no number; the forecaster's own chance of this, stated with the estimate: 80%; the middle value lies on the limit itself.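

No step from compound 1, compound 2 or compound 3 to compound 4 can be read, because each value is a limit and not a number: the limit of > 100000 nM in this assay, at which 4 of the 4 values shown sit.

The compounds shown leave open what exact value any of them has in this assay, and whether changing the substituent on the benzyl group alters it at all.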